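Two dimethylphenyl ureas flank a trichlorophenyl outlier

The compounds below may be only part of what the source reports. "The series", "measured", "known", "first", "only" and "open" are said of these compounds alone.

Measured compounds:
compound 1, `COc1cc(Nc2ncnc3c(NC(=O)Nc4ccc(C)c(C)c4)cccc23)cc(OC)c1`, 8.8 nM
compound 2, `COc1cc(Nc2ncnc3c(NC(=O)Nc4cc(Cl)c(Cl)cc4Cl)cccc23)cc(OC)c1`, 4890 nM

Both compounds were tested in a functional assay on RT-112 cells (Homo sapiens) for antiproliferative activity, read by MTT assay, with a stated time of 72 h; on this read-out higher numbers stand for weaker inhibition of growth and lower numbers for stronger inhibition of growth. Among the compounds with values here, compound 2 stands at the highest of the two numbers, with compound 1 as its only neighbour, a 560-fold higher number from compound 1 to compound 2 (2.74 log units; beyond the scatter) step away. Compound 3, `COc1cc(Nc2ncnc3c(NC(=O)Nc4cccc(C)c4C)cccc23)cc(OC)c1`, has not yet been measured. It differs from compound 2 in one place: 2,3-dimethylphenyl in place of 2,4,5-trichlorophenyl on an amide-type nitrogen. Within the data shown here, the only measured step that bears on this change is the one from compound 1 to compound 2, which was a 560-fold higher number from compound 1 to compound 2 (2.74 log units; beyond the scatter) when 2,4,5-trichlorophenyl replaced 3,4-dimethylphenyl. Compound 3 carries a dimethylphenyl group again, so a large step back toward lower numbers is expected in this assay, though the shift of one methyl relative to compound 1 leaves room for some difference. The expected step is a 160-fold lower number from compound 2 to compound 3 (2.21 log units; beyond the scatter). Compound 3 is therefore estimated at 30 nM, within a range of 5 nM to 300 nM.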

Compound 3, concentration for 50% growth inhibition: 5910 nM
Compound 3: middle estimate off by 200-fold (2.29 log units), on the low side; measured number outside the range, above it.
By their numbers in this assay, from the lowest: compound 1; then compounds 2 and 3 (each within the scatter of the next).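

In this assay, 2,3-dimethylphenyl in place of 3,4-dimethylphenyl on the amide-type nitrogen gives a 670-fold higher number from compound 1 to compound 3 (2.83 log units; beyond the scatter), so a dimethylphenyl group as such does not carry the low number of compound 1; where the two methyl groups sit on the ring matters here. 2,3-dimethylphenyl in place of 2,4,5-trichlorophenyl gives a 1.2-fold higher number from compound 2 to compound 3 (0.08 log units; within the scatter), so these two groups, though different in their atoms, cannot be told apart in this read-out. Of the three groups shown at this position, only 3,4-dimethylphenyl stands apart, with compound 2 and compound 3 both beyond the scatter from compound 1.

Nothing measured here explains why the placement of the methyl groups has so large an effect. Going by these compounds, it also remains open whether an unsubstituted phenyl, a methoxyphenyl or a pyridine at this position would stay near compound 1 or fall with compound 2 and compound 3.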